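Clearance notes on an aminopyrazolopyridine-type series

The compounds below may be only part of what the source reports. "The series", "measured", "known", "first", "only" and "open" are said of these compounds alone.

Measured so far:
- compound 1 `CCCN(CC1CCOCC1)c1c(CC)nn2c(-c3c(OC)cc(COC)cc3OC)cccc12`: 700 mL.min-1.g-1
- compound 2 `CCc1nn2c(-c3c(C)cc(C)cc3OC)cccc2c1N(CCCF)CC1CC1`: 1410 mL.min-1.g-1
- compound 3 `COCc1cc(OC)c(-c2cccc3c(N(CC4CCOCC4)CC4CC4)c(C#N)nn23)c(OC)c1`: 1100 mL.min-1.g-1

All three numbers come from an in vitro ADME assay on microsomes from liver (Homo sapiens) for metabolic stability, with a stated time of 15 min; on this read-out lower numbers stand for slow clearance and higher numbers for fast clearance. In this assay compound 1 gives 700 mL.min-1.g-1, compound 3 gives 1100 mL.min-1.g-1 and compound 2 gives 1410 mL.min-1.g-1. The number for compound 2 is the largest of the three, but it does not stand apart: its gap to compound 3 and its gap to compound 1 both lie within the scatter, so the three compounds cannot be ranked against one another on this read-out. The three differ from each other in more than one place, so no single change can be tied to any of these numbers.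

Compound 4 `CCc1nn2c(-c3c(C)cc(C)cc3OC)cccc2c1N(CC1CC1)CC1CCCO1` is not yet measured. It differs from compound 2 in one place: oxolan-2-yl in place of 2-fluoroethyl on a saturated chain carbon bound to a nitrogen on an aromatic ring. Among the compounds with values here, no measured pair in the set shows this kind of change, so there is no step on which to lean. The working assumption is that compound 4 stays in the same region as compound 2, and the expected step of a 1.2-fold lower number from compound 2 to compound 4 (0.07 log units; within the scatter) is none beyond the scatter. Compound 4 is therefore estimated at 1200 mL.min-1.g-1 in this assay, within a range of 500 mL.min-1.g-1 to 2800 mL.min-1.g-1.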

Compound 4, intrinsic clearance in microsomes: 1230 mL.min-1.g-1
For compound 4 the middle estimate is 1.0-fold (0.01 log units) below the measured one, within the range that was stated.
By their numbers in this assay, from the lowest: compounds 1, 3, 4 and 2 (each within the scatter of the next).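

Within the data shown here, the step of a 1.1-fold lower number from compound 2 to compound 4 (0.06 log units; within the scatter) is the first one that can be read at a single place, and it is measured in this assay. Among these compounds, at this place on a saturated chain carbon bound to a nitrogen on an aromatic ring, exchanging 2-fluoroethyl with its 3 heavy atoms and no ring for oxolan-2-yl with its 5 heavy atoms, one five-membered non-aromatic ring and 1 hydrogen-bond acceptor leaves compound 2 and compound 4 indistinguishable on this read-out, which the earlier compounds, all differing in more than one place, could not show. Nothing at hand bears on why the two numbers sit so close together.

Still open, going by these compounds, is whether an amine, a carboxylic acid or a longer chain at this same place would also stay within the scatter of compound 2. This single pair also leaves open whether the exchange of 3-fluoropropyl for (oxolan-2-yl)methyl would read the same with the other substituents carried by compound 1 and compound 3.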